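This account rests on a few compounds, and the source may have more. Where it says the series, first, only, none or still open, it means among the compounds named here.

Of the compounds shown here, two have so far been measured in a functional assay on PC-12 cells (Rattus norvegicus) for cytotoxicity, read by MTT assay, with stated times of 2 h and 24 h, tested at 5 uM; a higher number here means a stronger effect of the compound at the concentration tested, a lower number a weaker effect. Compound 1 `CCc1ccc(-n2nc(-c3ccc(C(F)(F)F)cc3O)nc2-c2ccccc2O)cc1` gives 95.4%. Compound 2 `COc1ccc(-n2nc(-c3ccc(C(F)(F)F)cc3O)nc2-c2ccccc2O)cc1` gives 86.6%; it stands lowest of the two numbers, but its nearest neighbour is compound 1, and the step of a number 8.8 percentage points lower from compound 1 to compound 2 (within the scatter) lies within the scatter. Compound 3 `Oc1cc(C(F)(F)F)ccc1-c1nc(-c2ccccc2O)n(-c2ccccc2Cl)n1` is not yet measured. It differs from compound 2 in one place: 2-chlorophenyl in place of 4-methoxyphenyl on an aromatic nitrogen. For the measured compounds named here, the only measured step bears on this in that it also altered the aromatic group on the aromatic nitrogen of the shared core, and there the read-out did not move beyond the scatter. Going by the values given here, no step with 2-chlorophenyl has been measured, so the expectation rests on that one comparison alone. No step beyond the scatter is expected, and the step this estimate implies is a number 0.6 percentage points lower from compound 2 to compound 3 (within the scatter). Compound 3 is expected to give 86% in this assay, with a range from 68% to 98%.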

Compound 3, a percentage reported as activity, at one concentration (the size of the read-out at that concentration, not a potency): 90.6%
Beside the measured number, compound 3's estimate is 4.6 percentage points below it; low and high end bracket the measured number.
By their numbers in this assay, from the lowest: compounds 2, 3 and 1 (each within the scatter of the next).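

At this aromatic nitrogen of the shared core, this assay now includes a 2-chlorophenyl group, and the change from 4-methoxyphenyl gives a number 4 percentage points higher from compound 2 to compound 3 (within the scatter), while the change from 4-ethylphenyl gives a number 4.8 percentage points lower from compound 1 to compound 3 (within the scatter). For the compounds shown here, the earlier step compared only two 4-substituted phenyl groups, whereas these steps show that the read-out also stays within the scatter with a 2-chlorophenyl group, which differs from both in its substituent and in the number in its name. Nothing measured here offers an explanation for this result.

As far as these compounds go, whether a phenyl group bearing an amine or a carboxylic acid, or a cyclohexyl group with no aromatic ring, would move the read-out at this nitrogen remains open. From the compounds shown here alone, the trifluoromethyl and both hydroxyl groups are shared by all three compounds, so their contribution also remains open.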